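Hydroxy for bromo on a nicotinoyl hydrazone: cytotoxicity outlook

The compounds below may be only part of what the source reports. "The series", "measured", "known", "first", "only" and "open" are said of these compounds alone.

Two hydrazones built on a shared core have been tested for how much compound cells tolerate. Compound 1, `O=C(N/N=C/c1cccc(Cl)c1)c1cccnc1`, in an ADME assay on HeLa cells (Homo sapiens) for cytotoxicity, read by microscopy (a higher number here means that more compound is tolerated, a lower number that less compound is tolerated), gives > 100 ug/mL, which is a limit of the assay rather than a number. Compound 2, `O=C(N/N=C/c1cccc(Br)c1)c1cccnc1`, carries bromo in place of chloro on an aromatic carbon. In this assay compound 2 gives >= 100 ug/mL, again a limit. The step that the two limits leave unreadable from compound 1 to compound 2 cannot be read, because both values sit at the limits the limit of > 100 ug/mL in this assay, at which 1 of the 2 values shown sits, and (the limit of >= 100 ug/mL in this assay, at which 1 of the 2 values shown sits). Compound 2 therefore stands at the edge of what this assay reports, with both shown values being limits. Compound 3, `O=C(N/N=C/c1cccc(O)c1)c1cccnc1`, differs from compound 2 by hydroxy in place of bromo on an aromatic carbon. No measured step touches hydroxy, and the only step shown is unreadable, so nothing points to a change beyond the scatter. Compound 3 is thus expected to give 100 ug/mL, between 50 ug/mL and 200 ug/mL. The step of a number no higher from compound 2 to compound 3 (the limit leaves the size open) is expected to stay within the scatter.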

Compound 3, minimum cytotoxic concentration: > 100 ug/mL
Compound 3 was reported as a limit; the forecaster's own chance of this, stated with the estimate: 75%; the middle value sits exactly at the limit.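

In this assay compound 3 gives > 100 ug/mL, which is a limit. The steps from compound 1 and compound 2 to compound 3 cannot be read. The compounds shown leave open how much of each compound is tolerated and whether chloro, bromo and hydroxy differ at all.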